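The compounds below may be only part of what the source reports. "The series", "measured", "known", "first", "only" and "open" are said of these compounds alone.

In a functional assay on A549 cells (Homo sapiens) for cytotoxicity, read by MTT assay, with a stated time of 48 h (a lower number here means a stronger inhibitor, a higher number a weaker inhibitor), compound 1 `C=CCSc1nnc(-c2cc(OC)c(OC)c(OC)c2)n1N1C(=O)c2ccccc2C1=O` gives > 200000 nM, which is a limit of the assay rather than a number. Compound 2 `COc1cc(-c2nnc(SCC(=O)c3ccc(Cl)cc3)n2N2C(=O)c3ccccc3C2=O)cc(OC)c1OC` gives 9030 nM in this assay. Compound 3 `COc1ccc(C(=O)CSc2nnc(-c3cc(OC)c(OC)c(OC)c3)n2N2C(=O)c3ccccc3C2=O)cc1` gives 30000 nM in this assay, the higher of the two numbers shown; the difference appears in the step of a 3.3-fold higher number from compound 2 to compound 3 (0.52 log units; beyond the scatter). Compound 4 `COc1cc(-c2nnc(SCC(=O)c3ccc(Br)cc3)n2N2C(=O)c3ccccc3C2=O)cc(OC)c1OC` carries bromo in place of methoxy on an aromatic carbon. Going by the values given here, the measured step that bears directly on this place is the one from compound 2 to compound 3, where chloro gave way to methoxy; the steps of an at least 22-fold lower number from compound 1 to compound 2 (1.34 log units; beyond the scatter) and an at least 6.6-fold lower number from compound 1 to compound 3 (0.82 log units; beyond the scatter) both start from the limit of > 200000 nM in this assay, at which 1 of the 3 values shown sits, and so only set a floor on how far a carbonyl-bearing group lowers the number. Since the step of a 3.3-fold higher number from compound 2 to compound 3 (0.52 log units; beyond the scatter) ran from a halogen to methoxy, returning to a halogen, here bromo, is expected to roughly reverse it, giving a 3.3-fold lower number from compound 3 to compound 4 (0.52 log units; beyond the scatter). Compound 4 is therefore estimated at about 9000 nM in this assay, expected to lie between 4000 nM and 25000 nM.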

Compound 4, half-maximal inhibitory concentration: 16100 nM
The estimate for compound 4 lay 1.8-fold (0.25 log units) below the measured number; the measured number falls inside the stated range.
By their numbers in this assay, from the lowest: compounds 2, 4 and 3 (each within the scatter of the next, the first and the last beyond it). At a limit, above all of these: compound 1.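

In this assay, placing bromo on this aromatic carbon, para to a large group, gives a 1.9-fold lower number from compound 3 to compound 4 (0.27 log units; within the scatter), and replacing chloro with bromo gives a 1.8-fold higher number from compound 2 to compound 4 (0.25 log units; within the scatter). Compound 2 and compound 3 differ beyond the scatter, yet compound 4 cannot be separated from either, so these compounds do not show a clean divide between halogen and methoxy at this position. Compound 1 stands at a limit, so the step of an at least 12-fold lower number from compound 1 to compound 4 (1.09 log units; beyond the scatter) sets only a floor on what the (4-bromophenyl)carbonyl group brings: the limit of > 200000 nM in this assay, at which 1 of the 4 values shown sits.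

The compounds shown leave open how this position responds to quite different groups, such as an amine or a carboxylic acid. They also leave open whether any group here could clearly outdo compound 2, at 9030 nM.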